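Swapping Benzyloxy for (3,4-Dichlorophenyl)amino: Cytotoxicity Outlook

The source may hold more compounds than are shown below. What is called first, only, known or untested is meant among the compounds shown, and "the series" means these compounds.

Compound 1 `C=C[C@@](C)(/C=C/c1ccc(OCc2ccccc2)cc1)CCC=C(C)C` was examined in a functional assay on SEM cells (Homo sapiens) for cytotoxicity, with a stated time of 72 h; a higher number here means that more compound is needed for the effect, a lower number that less compound is needed. In this assay compound 1 reaches only the limit of > 36600 nM, so no number is known for it. The other measured compound, compound 2 `C=C[C@@](C)(/C=C/c1ccc(O)cc1)CC/C=C(C)/C=C/C(=O)OCc1ccccc1`, is in the same position: in this assay compound 2 gives > 36600 nM, again a limit rather than a number. Both values therefore sit at the limit of > 36600 nM in this assay, at which 2 of the 2 values shown sit, and compound 1 stands at the limit without a distinguishing figure. For the measured compounds named here, no step between measured compounds that differ in one place is available.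

Compound 3 `C=C[C@@](C)(/C=C/c1ccc(Nc2ccc(Cl)c(Cl)c2)cc1)CCC=C(C)C` has not yet been tested in this assay. It differs from compound 1 by (3,4-dichlorophenyl)amino in place of benzyloxy on an aromatic carbon. With both known values at the limit, the step from compound 1 to compound 3 is expected to be an at least 1.2-fold lower number from compound 1 to compound 3 (0.08 log units; that floor lies within the scatter), a modest gain or none beyond the scatter. Compound 3 is estimated at 30000 nM, with a range from 8000 nM to 100000 nM.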

Compound 3, half-maximal effective concentration: > 36600 nM
Compound 3: a limit, no number (the forecaster's own chance of this, stated with the estimate: 60%); middle value at least 1.2-fold (0.08 log units) away from the limit.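

Compound 1 and compound 3 both remain limits rather than numbers in this assay, so no step can be read between them: the limit of > 36600 nM in this assay, at which 3 of the 3 values shown sit.

The compounds shown leave open how much of any of them is needed for the effect, and whether (3,4-dichlorophenyl)amino in place of benzyloxy changes that amount.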